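Adding a Methoxy Group to Compound 2

This account rests on a few compounds, and the source may have more. Where it says the series, first, only, none or still open, it means among the compounds named here.

Only two results frame this small series, and just one of them is a true number. For the measured compounds named here, in a functional assay on MCF7 cells (Homo sapiens) for cytotoxicity, read by MTT assay, with a stated time of 72 h (on this read-out higher numbers stand for weaker inhibition and lower numbers for stronger inhibition), compound 2 `Cc1cc(/C=C/c2ccc(O)cc2)on1` gives 50200 nM, the only numerical value available so far. Compound 1 `COc1ccc(/C=C/c2cc(C)no2)cc1OC` is reported at > 100000 nM, which is a limit of the assay and not a number. Compound 2 is therefore the sole numerical reference point for what follows.

Compound 3 `COc1cc(/C=C/c2cc(C)no2)ccc1O` has yet to be measured in this assay. It departs from compound 2 in one place, methoxy in place of hydrogen on an aromatic carbon, ortho to a hydroxy group. Going by the values given here, no measured pair shows what this change does, so the expectation starts from compound 2 at 50200 nM and stays cautious.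

The expected result is no step beyond the usual scatter of this assay, with a 1.1-fold higher number from compound 2 to compound 3 (0.04 log units; within the scatter) as the estimated change. For compound 3 the estimated half-maximal inhibitory concentration is 55000 nM, with an expected range from 20000 nM to 100000 nM.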

Compound 3, half-maximal inhibitory concentration: 20900 nM
The estimate for compound 3 lay 2.6-fold (0.42 log units) above the measured number; the measured number falls inside the stated range.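

In this assay, for the compounds shown here, methoxy in place of hydrogen on an aromatic carbon, ortho to a hydroxy group, gives a 2.4-fold lower number from compound 2 to compound 3 (0.38 log units; beyond the scatter), the first measured step for this change at this position, and a modest one. Hydrogen in place of methyl on an oxygen on an aromatic ring gives an at least 4.7-fold lower number from compound 1 to compound 3 (0.67 log units; beyond the scatter), so among these three compounds the added methoxy goes with a lower number when the hydroxy group stays free, whereas compound 1, which carries methyl on that oxygen, yields no number at all. The size of that second step is only a bound, since compound 1 is reported at a limit of the assay and not at a number: the limit of > 100000 nM in this assay, at which 1 of the 3 values shown sits.

The compounds shown leave open whether the lower number belongs to methoxy itself or would also come with another group on the same carbon, such as ethoxy, a fluorine atom or an amine. They also leave open whether the hydroxy group could give way to a carboxylic acid or an amine while keeping the step seen with compound 3.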